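This account rests on a few compounds, and the source may have more. Where it says the series, first, only, none or still open, it means among the compounds named here.

Compound 1 `CC(C)=CCc1cc(/C=C/C(=O)O)cc2c1OC(C)(C)C(O)C2` gives 71.5 ug/mL in a functional assay on HT-1080 cells (Homo sapiens) for cytotoxicity, read by MTT assay, with a stated time of 24 h; a lower number here means that less compound is needed, a higher number that more compound is needed for the effect.
Compound 2 `C=C1CC[C@@H]2[C@](C)(CCC[C@]2(C)C(=O)O)[C@H]1CC/C(C)=C/CO` gives 72.9 ug/mL in this assay.
Compound 3 `C=C1CC[C@@H]2[C@](C)(CCC[C@]2(C)C(=O)O)[C@H]1CC/C(C)=C/C(=O)O` gives 75.4 ug/mL in this assay.

The three numbers lie within the usual scatter of one another, so compound 3 stands with compound 1 and compound 2 rather than apart from them; none of the three can be called more or less active than the others on these data.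

Compound 4 `C=C[C@](C)(O)CC[C@H]1C(=C)CC[C@@H]2[C@]1(C)CCC[C@]2(C)C(=O)O` differs from compound 3 in one place: 1-hydroxy-1-methylprop-2-en-1-yl in place of 2-carboxy-1-methylethenyl on a saturated chain carbon, two bonds along the chain from a saturated ring carbon. The chain that carried a carboxy group and a double bond is replaced by a chain of the other shape, carrying a hydroxy group and a double bond in a different position, with one defined stereocentre.

Among the compounds with values here, only one measured step bears on this change, and only in part. The step of a 1.0-fold higher number from compound 2 to compound 3 (0.01 log units; within the scatter) exchanged a hydroxymethyl for a carboxy on a double-bonded chain carbon and left the number essentially unchanged. Within the data shown here, the change from compound 3 to compound 4 runs in the opposite direction, carboxy leaving and a hydroxy group entering, together with a rearrangement of the chain for which no step is available. On that basis no step beyond the scatter is expected in this assay.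

Compound 4 is therefore estimated at 75 ug/mL, with a range from 40 ug/mL to 140 ug/mL. This estimate means a 1.0-fold lower number from compound 3 to compound 4 (0.00 log units; within the scatter).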

Compound 4, concentration for half-maximal effect: 94.9 ug/mL
For compound 4 the middle estimate is 1.3-fold (0.10 log units) below the measured one; low and high end bracket the measured number.
By their numbers in this assay, from the lowest: compounds 1, 2, 3 and 4 (each within the scatter of the next).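

In this assay the group on this saturated chain carbon can change shape without the number leaving the scatter: 1-hydroxy-1-methylprop-2-en-1-yl in place of 2-carboxy-1-methylethenyl gives a 1.3-fold higher number from compound 3 to compound 4 (0.10 log units; within the scatter) and the same group in place of 3-hydroxy-1-methylprop-1-en-1-yl gives a 1.3-fold higher number from compound 2 to compound 4 (0.11 log units; within the scatter) in this comparison. The earlier step changed only the end of a chain whose double bond stayed where it was, whereas these two steps show that a moved double bond and a hydroxy group on a defined stereocentre also produce no change beyond the scatter. No measurement shown here offers an explanation for this flat result.

The compounds shown leave open whether any group at this place can move the number beyond the scatter, since an amine, a longer chain and a phenyl ring are not among them. Going by these compounds, compound 2, compound 3 and compound 4 also all keep the carboxy group on the shared core, so what a methyl ester at that point would do stays open.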